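The compounds below may be only part of what the source reports. "The series", "measured", "known", "first", "only" and "open" are said of these compounds alone.

Measured compounds and their numbers in a functional assay on MCF7 cells (Homo sapiens) for inhibition, read by MTT assay, with a stated time of 48 h; on this read-out higher numbers stand for weaker inhibition and lower numbers for stronger inhibition:

compound 1, `CCOC(=O)c1c(N)sc(/N=C/c2ccco2)c1C(=O)OCC`: 62200 nM
compound 2, `CCOC(=O)c1c(N)sc(/N=C/c2ccc(C)cc2)c1C(=O)OCC`: 8900 nM
compound 3, `CCOC(=O)c1c(N)sc(/N=C/c2ccc([N+](=O)[O-])cc2)c1C(=O)OCC`: 1300 nM

Compound 1 stands at the top of these three numbers, that is, it is the weakest inhibitor among them. The step of a 7.0-fold lower number from compound 1 to compound 2 (0.84 log units; beyond the scatter) is modest, and the step of a 48-fold lower number from compound 1 to compound 3 (1.68 log units; beyond the scatter) is large; both lie beyond the scatter.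

Compound 4, `CCOC(=O)c1c(N)sc(/N=C/c2ccc([N+](=O)[O-])o2)c1C(=O)OCC`, keeps the core of compound 1 and differs from it in one place: nitro in place of hydrogen on an aromatic carbon

Two of the measured steps bear on this change. The step of a 6.8-fold lower number from compound 2 to compound 3 (0.84 log units; beyond the scatter) shows that a nitro group on an aromatic carbon, set in place of a methyl group, lowers the number by a modest amount. The step of a 48-fold lower number from compound 1 to compound 3 (1.68 log units; beyond the scatter) shows that a ring carrying a nitro group, set in place of the unsubstituted furan-2-yl group, lowers the number by a large amount. Within the data shown here, neither step is the very same change as the one from compound 1 to compound 4, since here the furan ring is kept and the nitro group is added to it, but both point the same way. A lowering of the number beyond the scatter is therefore expected for compound 4, of a size between modest and large, read as a 7.8-fold lower number from compound 1 to compound 4 (0.89 log units; beyond the scatter). Compound 4 is expected to give about 8000 nM in this assay, within a range from 2500 nM to 25000 nM.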

Compound 4, half-maximal inhibitory concentration: 2400 nM
Beside the measured number, compound 4's estimate is 3.3-fold (0.52 log units) above it; measured number below the stated range.
By their numbers in this assay, from the lowest: compounds 3 and 4 (each within the scatter of the next); then compound 2; then compound 1.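

In this assay, nitro in place of hydrogen on the aromatic carbon next to the ring oxygen, with the furan ring kept, gives a large change on its own (a 26-fold lower number from compound 1 to compound 4 (1.41 log units; beyond the scatter)), whereas the earlier large step to a nitro-bearing ring also exchanged the furan ring for a phenyl ring. Among the compounds carrying nitro, the ring itself does not separate the two: 5-nitrofuran-2-yl in place of 4-nitrophenyl leaves the pair within the scatter (a 1.8-fold higher number from compound 3 to compound 4 (0.27 log units; within the scatter)), while 5-nitrofuran-2-yl in place of 4-methylphenyl still gives a step beyond it (a 3.7-fold lower number from compound 2 to compound 4 (0.57 log units; beyond the scatter)). The data shown offer no measurement that would explain why this change acts as it does.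

The compounds shown leave open whether the large step belongs to nitro itself, since no other group, such as an amine, a carboxylic acid or a chlorine atom, appears at this furan position. They also leave open whether nitro would have a comparable effect on another carbon of the furan ring, or with the two ethyl esters of the core replaced.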